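Series notes: cyclopentyl to isopropyl, microsomal clearance

The compounds below may be only part of what the source reports. "The series", "measured", "known", "first", "only" and "open" are said of these compounds alone.

Measured so far:
compound 1 `Clc1ccc(-c2ccc(Cn3nnc4ccccc43)cc2)c(Cl)c1` gives 1.3 mL/min/g
compound 2 `Brc1cccc2c1nnn2CC1CCCC1` gives 11.4 mL/min/g

Both numbers come from an ADME assay on microsomes from liver (Mus musculus, strain NMRI) for metabolic stability, tested at 2.5 uM; on this read-out higher numbers stand for fast clearance and lower numbers for slow clearance. Of the two, compound 2 stands highest; compound 1 sits well below it, and that gap is beyond the scatter of repeated runs, so compound 2 is the faster-cleared of the two measured compounds. Compound 3 `CC(C)Cn1nnc2c(Br)cccc21` has not yet been run in this assay. It differs from compound 2 in one place: isopropyl in place of cyclopentyl on a saturated chain carbon bound to an aromatic nitrogen. Within the data shown here, no measured pair in this set carries a change of that kind, so no step size can be read off the data for it. The expectation for compound 3 is a modest shift towards slower clearance, not clearly beyond the scatter, as the step of a 1.6-fold lower number from compound 2 to compound 3 (0.21 log units; within the scatter) is expected to show. In this assay compound 3 is estimated at 7 mL/min/g, with a range from 3 mL/min/g to 14 mL/min/g.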

Compound 3, intrinsic clearance in a liver preparation (reported as CLH), per the amount of preparation that the assay uses: 3.5 mL/min/g
For compound 3 the middle estimate is 2.0-fold (0.30 log units) above the measured one, and the stated range covers the measured number.
By their numbers in this assay, from the lowest: compound 1; then compound 3; then compound 2.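

In this assay, isopropyl in place of cyclopentyl on a saturated chain carbon bound to an aromatic nitrogen gives a 3.3-fold lower number from compound 2 to compound 3 (0.51 log units; beyond the scatter), so a single change at this position moves clearance beyond the scatter. The change replaces a five-membered non-aromatic ring of carbon only with a group with no ring, taking the heavy atoms from 5 to 3 while adding no hydrogen-bond donors or acceptors, though this rests on one pair only. Nothing available accounts for the size or direction of this step.

Still open, going by these compounds, is whether the step follows the loss of the ring or the smaller heavy-atom count; a pentyl chain or a cyclopropyl group at this place would separate the two. Also open, on these data alone, is how an amine or a carboxylic acid there would read in this assay.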